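The source may report more compounds than this note shows. Statements on the series, on what has been measured and on what is new or still open speak of the compounds shown alone.

Measured compounds in an assay on brain for displacement of a labelled ligand from D(3) dopamine receptor (Rattus norvegicus); a lower number here means a stronger inhibitor, a higher number a weaker inhibitor:
compound 1 `CCCN(CC[C@H]1CC[C@H](NC(=O)c2cccc3ncccc23)CC1)[C@H]1CCc2nc(N)sc2C1` gives 1.6 nM
compound 2 `CCCN(CC[C@H]1CC[C@H](NC(=O)c2cccc(-n3cncn3)c2)CC1)[C@H]1CCc2nc(N)sc2C1` gives 3 nM

Among the compounds with values here, compound 2 carries the higher of the two numbers, with compound 1 as its only neighbour; the step of a 1.9-fold higher number from compound 1 to compound 2 (0.27 log units; within the scatter) replaces quinolin-5-yl by 3-(1H-1,2,4-triazol-1-yl)phenyl on the carbonyl carbon and stays within the scatter, so the two compounds cannot be ordered on this assay.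

Compound 3 `CCCN(CC[C@H]1CC[C@H](NC(=O)c2ccc(-n3cncn3)cc2)CC1)[C@H]1CCc2nc(N)sc2C1` has not been measured. It differs from compound 2 by 4-(1H-1,2,4-triazol-1-yl)phenyl in place of 3-(1H-1,2,4-triazol-1-yl)phenyl on a carbonyl carbon, the same atoms joined differently. Within the data shown here, no measured step moves the triazolyl group around the phenyl ring; the only measured step changes the whole aryl group and is itself small. There is therefore no basis in the numbers for expecting a step beyond the scatter in this assay, though the shown data do not exclude one.

The estimated step from compound 2 to compound 3 is a 1.7-fold higher number from compound 2 to compound 3 (0.22 log units; within the scatter). Compound 3 is expected to give about 5 nM in this assay, with a plausible range from 1.5 nM to 20 nM.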

Compound 3, inhibition constant: 2.4 nM
For compound 3 the middle estimate is 2.1-fold (0.32 log units) above the measured one; low and high end bracket the measured number.
By their numbers in this assay, from the lowest: compounds 1, 3 and 2 (each within the scatter of the next).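

In this assay, within the data shown here, exchanging 3-(1H-1,2,4-triazol-1-yl)phenyl for 4-(1H-1,2,4-triazol-1-yl)phenyl on the carbonyl carbon bearing the amide-type nitrogen gives a 1.3-fold lower number from compound 2 to compound 3 (0.10 log units; within the scatter) and thus supplies the first measured change in where the triazolyl group sits on the phenyl ring; this change cannot be told from the scatter. Replacing quinolin-5-yl with the same 4-(1H-1,2,4-triazol-1-yl)phenyl group gives a 1.5-fold higher number from compound 1 to compound 3 (0.18 log units; within the scatter), so both triazolylphenyl isomers now lie within the scatter of quinolin-5-yl, and the three aryl groups cannot be ordered in this assay. Nothing available accounts for this flat result.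

The compounds shown leave open whether the flat result extends to aryl groups without the triazolyl ring, such as plain phenyl or a phenyl carrying a carboxylic acid or an amine in its place. They also leave open whether a step beyond the scatter would appear with an aliphatic group, such as a longer alkyl chain, on this carbonyl carbon.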